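Lengthening a Hydroxamic Acid Chain on a Shared Core

A few compounds are considered here, and "the series" means these few. Any claim that something is new, unique, unknown or untested is made for them only; others in the source may bear on it.

Compound 2 `Nc1ncnc2c1c(-c1cnc3[nH]ccc3c1)nn2CCCCC(=O)NO` gives only a limit in a functional assay on CNE-2 cells (Homo sapiens) for inhibition, read by MTT assay, with a stated time of 72 h (a higher number here means a weaker inhibitor, a lower number a stronger inhibitor), namely > 150000 nM, one of the values at the limit of > 150000 nM in this assay, at which 1 of the 2 values shown sits. Compound 1 `CNC(=O)CCCCCCCn1nc(-c2cnc3[nH]ccc3c2)c2c(N)ncnc21`, with a longer chain ending in a methylcarbamoyl group, gives 8990 nM in this assay. Among the compounds with values here, the one measured step, an at least 16-fold higher number from compound 1 to compound 2 (1.22 log units; beyond the scatter), shows the short hydroxycarbamoyl compound clearly weaker. Compound 3 `Nc1ncnc2c1c(-c1cnc3[nH]ccc3c1)nn2CCCCCCC(=O)NO` differs from compound 2 by 2-(hydroxycarbamoyl)ethyl in place of hydroxycarbamoyl on a saturated chain carbon, four bonds along the chain from an aromatic nitrogen, bringing its chain length closer to that of compound 1. A gain is therefore expected, with the step of an at least 25-fold lower number from compound 2 to compound 3 (1.39 log units; beyond the scatter). Compound 3 is estimated at 6000 nM, between 1000 nM and 60000 nM.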

Compound 3, half-maximal inhibitory concentration: 19500 nM
Beside the measured number, compound 3's estimate is 3.3-fold (0.51 log units) below it; measured number inside the range.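

Chain length at this position clearly matters: 2-(hydroxycarbamoyl)ethyl in place of hydroxycarbamoyl gives an at least 7.6-fold lower number from compound 2 to compound 3 (0.88 log units; beyond the scatter) in this assay. On these data alone, the true size of that gain is unknown, since the value for compound 2 is a limit and not a number: the limit of > 150000 nM in this assay, at which 1 of the 3 values shown sits. The longer hydroxycarbamoyl chain still does not match the methylcarbamoyl-ended chain, with a modest gap of a 2.2-fold higher number from compound 1 to compound 3 (0.34 log units; beyond the scatter).

As far as these compounds go, whether a still longer hydroxycarbamoyl chain would strengthen inhibition further remains open. So does the effect of a carboxylic acid at the chain end.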